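This account rests on a few compounds, and the source may have more. Where it says the series, first, only, none or still open, it means among the compounds named here.

In an ADME assay on Vero cells (Chlorocebus sabaeus) for cytotoxicity, read by reporter gene assay, with a stated time of 4 days (on this read-out lower numbers stand for stronger inhibition and higher numbers for weaker inhibition), compound 1 (`CCCCCCCC(=O)OCC(C)(C)CC1=C(O)C(=O)c2ccccc2C1=O`) gives only a limit, > 258000 nM. Compound 2 (`CCCCCCC(C)C(=O)OCC(C)(C)CC1=C(O)C(=O)c2ccccc2C1=O`) gives 450 nM, and the step is an at least 570-fold lower number from compound 1 to compound 2 (2.75 log units; beyond the scatter). Compound 3 (`CCCCCCCCCCCC(=O)OCC(C)(C)CC1=C(O)C(=O)c2ccccc2C1=O`) differs from compound 1 by butyl in place of hydrogen on a saturated chain carbon, seven bonds along the chain from a carbonyl carbon. Going by the values given here, the only measured step on this chain is that from compound 1 to compound 2, an at least 570-fold lower number from compound 1 to compound 2 (2.75 log units; beyond the scatter), and it lies at a different chain carbon, so it is weak guidance. A lower number is expected, by a much smaller step: an at least 6.4-fold lower number from compound 1 to compound 3 (0.80 log units; beyond the scatter) is the estimated change. For compound 3 the estimated value is 40000 nM, with an expected range of 5000 nM to 258000 nM.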

Compound 3, half-maximal inhibitory concentration: 249000 nM
The estimate for compound 3 lay 6.2-fold (0.79 log units) below the measured number; measured number inside the range.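

In this assay, butyl in place of hydrogen on a saturated chain carbon, seven bonds along the chain from a carbonyl carbon, gives an at least 1.0-fold lower number from compound 1 to compound 3 (0.01 log units; that floor lies within the scatter). Unlike the methyl step at a different chain carbon, an at least 570-fold lower number from compound 1 to compound 2 (2.75 log units; beyond the scatter), this change shows no lowering that can be told from the scatter. Its true size cannot be fixed, because compound 1 has only a limit: the limit of > 258000 nM in this assay, at which 1 of the 3 values shown sits. From the compounds shown here alone, whether an ethyl, a phenyl or an amine in place of hydrogen on this carbon would lower the number stays open.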